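The source may report more compounds than this note shows. Statements on the series, on what has been measured and on what is new or still open speak of the compounds shown alone.

In a functional assay on HL-60 cells (Homo sapiens) for cytotoxicity, read by MTT assay, with a stated time of 24 h (a higher number here means a weaker inhibitor, a lower number a stronger inhibitor), compound 1 `OCCOc1c(Br)cc(Br)cc1Oc1ccc(Br)cc1Br` gives 28.2 ug/mL. Compound 2 `BrCCCCCCOc1c(Br)cc(Br)cc1Oc1ccc(Br)cc1Br` gives 37.8 ug/mL in this assay and stands alongside compound 1, since a 1.3-fold higher number from compound 1 to compound 2 (0.13 log units; within the scatter) lies within the scatter. Compound 3 `CN1CCN(CCCCCOc2c(Br)cc(Br)cc2Oc2ccc(Br)cc2Br)CC1` differs from compound 2 by 4-methylpiperazin-1-yl in place of bromomethyl on a saturated chain carbon, five bonds along the chain from an oxygen on an aromatic ring. Among the measured compounds shown here, no measured step bears directly on this change at the far end of the chain; the only known step, a 1.3-fold higher number from compound 1 to compound 2 (0.13 log units; within the scatter), altered the same chain and stayed within the scatter, so no step beyond the scatter is expected in this assay here. Compound 3 is therefore estimated at 30 ug/mL, with a range from 10 ug/mL to 90 ug/mL. That expectation amounts to a 1.3-fold lower number from compound 2 to compound 3 (0.10 log units; within the scatter).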

Compound 3, half-maximal inhibitory concentration: 48.3 ug/mL
For compound 3 the middle estimate is 1.6-fold (0.21 log units) below the measured one, within the range that was stated.
By their numbers in this assay, from the lowest: compounds 1, 2 and 3 (each within the scatter of the next).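

In this assay, 4-methylpiperazin-1-yl in place of bromomethyl gives a small change (a 1.3-fold higher number from compound 2 to compound 3 (0.11 log units; within the scatter)), and the comparison with the hydroxy end group is also small (a 1.7-fold higher number from compound 1 to compound 3 (0.23 log units; within the scatter)). The far end of the chain, five bonds along from an oxygen on an aromatic ring, thus accepts a ring-bearing amine without a step beyond the scatter, which the earlier pair could not show. No evidence here offers an explanation for this. As far as these compounds go, whether a carboxylic acid or a shorter chain at this place would behave alike remains open.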